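This account rests on a few compounds, and the source may have more. Where it says the series, first, only, none or still open, it means among the compounds named here.

Measured so far:
- compound 1 `O=C(N/N=C/c1ccccc1O)c1ccc(-c2ccc(F)cc2)o1`: > 40000 nM
- compound 2 `COc1ccccc1/C=N/NC(=O)c1ccc(-c2ccc(F)cc2F)o1`: > 40000 nM

In a functional assay on KB cells (Homo sapiens) for antiproliferative activity, read by sulforhodamine B assay, with a stated time of 48 h (on this read-out higher numbers stand for weaker inhibition and lower numbers for stronger inhibition), compound 2 gives > 40000 nM, which is a limit of the assay and not a number. Compound 1 likewise reaches only a limit, > 40000 nM, in this assay. For the measured compounds named here, both values shown sit at the limit of > 40000 nM in this assay, at which 2 of the 2 values shown sit, so neither compound gives a figure to compare against the other, and no step between measured compounds can be drawn.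

Going by the values given here, compound 3 `O=C(N/N=C/c1ccccc1O)c1ccc(-c2ccc(F)cc2F)o1` differs from compound 2 by hydrogen in place of methyl on an oxygen on an aromatic ring; the hydroxy group it gains is the one carried by compound 1. With both neighbours of compound 3 sitting at the limit, no direction of change is expected beyond the scatter. For compound 3 the estimate is 60000 nM, with a range from 20000 nM to 250000 nM. The step this estimate means, a step that the limit leaves unreadable from compound 2 to compound 3, is expected to be none beyond the scatter, and most likely the assay again reports only its limit.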

Compound 3, half-maximal inhibitory concentration: > 40000 nM
Compound 3 was reported as a limit; the forecaster's own chance of this, stated with the estimate: 85%; the middle value does not contradict the limit.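

Compound 1, compound 2 and compound 3 all stand at a limit of the assay in this assay, so no step among them can be read: the limit of > 40000 nM in this assay, at which 3 of the 3 values shown sit.

The compounds shown leave open whether hydroxy in place of methoxy, or fluoro in place of hydrogen, changes the read-out at all.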